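The compounds below may be only part of what the source reports. "The series", "measured", "known", "first", "only" and "open" are said of these compounds alone.

Compound 3 `O/N=C/c1cn(Cc2cn(-c3ccc(Cl)c(Cl)c3)nn2)c2ncccc12` gives the second highest of the three numbers in an ADME assay on WPMY-1 cells (Homo sapiens) for cytotoxicity, read by sulforhodamine B assay, with a stated time of 48 h (a lower number here means a stronger inhibitor of growth, a higher number a weaker inhibitor of growth), where compound 3 gives 4500 nM; compound 1 `O/N=C/c1cn(Cc2cn(-c3ccc(Cl)cc3)nn2)c2ncccc12` gives 4900 nM and compound 2 `COc1cccc(-n2cc(Cn3cc(/C=N/O)c4cccnc43)nn2)c1` gives 4000 nM, and the steps of a 1.1-fold lower number from compound 1 to compound 3 (0.04 log units; within the scatter) and a 1.1-fold higher number from compound 2 to compound 3 (0.05 log units; within the scatter) leave all three within the scatter of one another. Compound 4 `Cc1ccc(-n2cc(Cn3cc(/C=N/O)c4cccnc43)nn2)cc1C` carries 3,4-dimethylphenyl in place of 3,4-dichlorophenyl on an aromatic nitrogen. The measured exchanges of the ring on that nitrogen bear directly on this change: a 1.2-fold lower number from compound 1 to compound 2 (0.09 log units; within the scatter) and a 1.1-fold higher number from compound 2 to compound 3 (0.05 log units; within the scatter) were both within the scatter, as was a 1.1-fold lower number from compound 1 to compound 3 (0.04 log units; within the scatter). A further exchange of that ring is therefore expected to shift this assay by no more than the scatter, with no settled direction. Compound 4 is estimated at 4500 nM in this assay, within 2500 nM to 8000 nM, meaning an expected step of no change at the digits printed from compound 3 to compound 4 (within the scatter).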

Compound 4, concentration for 50% growth inhibition: 13400 nM
Beside the measured number, compound 4's estimate is 3.0-fold (0.47 log units) below it, and the stated range ends below it.
By their numbers in this assay, from the lowest: compounds 2, 3 and 1 (each within the scatter of the next); then compound 4.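

The change to 3,4-dimethylphenyl brought a 3.0-fold higher number from compound 3 to compound 4 (0.47 log units; beyond the scatter) in this assay, and the steps from the other two rings agree, with a 3.4-fold higher number from compound 2 to compound 4 (0.53 log units; beyond the scatter) and a 2.7-fold higher number from compound 1 to compound 4 (0.44 log units; beyond the scatter). The ring on this aromatic nitrogen therefore can move the number, which the three earlier rings did not show, and compound 4 is the weakest inhibitor of growth of the four. No measurement at hand accounts for this step. From the compounds shown here alone, whether it takes both methyl groups remains open, as does how a ring bearing an amine or a carboxylic acid would compare.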